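Swapping the aryl group on an aromatic nitrogen

The source may hold more compounds than are shown below. What is called first, only, known or untested is meant among the compounds shown, and "the series" means these compounds.

Compound 1 `COc1ccc(-n2ccc(=O)c(C(=O)Nc3ccc(Oc4ccnc5[nH]ccc45)cc3)n2)cc1` and compound 2 `COc1ccc(-n2ccc(=O)c(C(=O)Nc3ccc(Oc4ccnc5c4ccn5C)cc3)n2)cc1` share one core and differ only by a methyl on an aromatic nitrogen. In a functional assay on PC-3 cells (Homo sapiens) for cytotoxicity, read by MTT assay, with a stated time of 72 h (on this read-out lower numbers stand for stronger inhibition and higher numbers for weaker inhibition), compound 1 gives > 60000 nM, which is a limit of the assay rather than a number. In this assay compound 2 likewise gives > 60000 nM, again a limit. The step that the two limits leave unreadable from compound 1 to compound 2 therefore cannot be read, because the limit of > 60000 nM in this assay, at which 2 of the 2 values shown sit, holds both values. Compound 3 `Cn1ccc2c(Oc3ccc(NC(=O)c4nn(-c5ccc(Cl)c(C(F)(F)F)c5)ccc4=O)cc3)ccnc21` keeps the methylated core of compound 2 and carries 4-chloro-3-(trifluoromethyl)phenyl in place of 4-methoxyphenyl on an aromatic nitrogen, that is, 4-chloro-3-(trifluoromethyl)phenyl in place of 4-methoxyphenyl on an aromatic nitrogen. Among the measured compounds shown here, no measured step covers this change, so the only guide is that compound 2 sits at the limit. Compound 3 is expected to reach an estimated 20000 nM, within a range from 2000 nM to 60000 nM, and the step of an at least 3.0-fold lower number from compound 2 to compound 3 (0.47 log units; beyond the scatter) is itself only an expectation.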

Compound 3, half-maximal inhibitory concentration: 10300 nM
Compound 3: middle estimate off by 1.9-fold (0.29 log units), on the high side; low and high end bracket the measured number.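

In this assay, 4-chloro-3-(trifluoromethyl)phenyl in place of 4-methoxyphenyl on the aromatic nitrogen gives an at least 5.8-fold lower number from compound 2 to compound 3 (0.76 log units; beyond the scatter), so the aryl group at this position changes the read-out by more than the usual scatter. Among the compounds shown here, compound 3, at 10300 nM, is the only one of the three with a measured number rather than a limit, and it gives the first readable step, since the methyl step between the earlier compounds cannot be read. The true size of the new step remains unknown because compound 2 stands at a limit: the limit of > 60000 nM in this assay, at which 2 of the 3 values shown sit.

As far as these compounds go, the chlorine and the trifluoromethyl enter together, so the share of each in the step stays open. Also open, from the compounds shown here alone, are how an amine or a carboxylic acid on this aryl ring would read, and whether the methyl on the core matters alongside the new aryl group.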